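The source may report more compounds than this note shows. Statements on the series, on what has been measured and on what is new or still open speak of the compounds shown alone.

Going by the values given here, compound 2 `O=C(O)c1ccccc1-c1ccc(CCc2ncc(C3CCCCC3)[nH]2)cc1` gives 375 nM in an in vitro functional assay on cells for agonist activity at Bombesin receptor subtype-3 (Homo sapiens), read by luminescence and calcium flux (on this read-out lower numbers stand for an effect already at smaller amounts and higher numbers for an effect only at larger amounts of compound), the lowest of the three numbers measured so far. Compound 1 `O=C(O)c1ccccc1-c1ccc(CCc2ncc(CC3CCC3)[nH]2)cc1` gives 588 nM, and the difference a 1.6-fold lower number from compound 1 to compound 2 (0.20 log units; within the scatter) lies within the scatter. Compound 3 `COc1ccc(Cc2cnc(CCc3ccc(-c4ccccc4C(=O)O)cc3)[nH]2)cc1` gives 5360 nM, and the step of a 14-fold higher number from compound 2 to compound 3 (1.16 log units; beyond the scatter) is large. Compound 4 `N#Cc1cccc(Cc2cnc(CCc3ccc(-c4ccccc4C(=O)O)cc3)[nH]2)c1` differs from compound 2 by 3-cyanobenzyl in place of cyclohexyl on an aromatic carbon. The closest guide is the step of a 14-fold higher number from compound 2 to compound 3 (1.16 log units; beyond the scatter), in which a substituted benzyl group likewise took the place of the cyclohexyl; the step of a 9.1-fold higher number from compound 1 to compound 3 (0.96 log units; beyond the scatter) points the same way. A step in the same direction and of similar size is therefore expected: an 11-fold higher number from compound 2 to compound 4 (1.03 log units; beyond the scatter). Compound 4 is expected to give 4000 nM, with a range from 1500 nM to 12000 nM.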

Compound 4, half-maximal effective concentration: 812 nM
Compound 4: the middle estimate sits 4.9-fold (0.69 log units) above what was measured; measured number below the stated range.
By their numbers in this assay, from the lowest: compounds 2, 1 and 4 (each within the scatter of the next, the first and the last beyond it); then compound 3.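

A benzyl group at this position need not cost much: a 2.2-fold higher number from compound 2 to compound 4 (0.34 log units; beyond the scatter) is only a modest step, and a 1.4-fold higher number from compound 1 to compound 4 (0.14 log units; within the scatter) stays within the scatter. What the benzyl ring carries clearly matters, since a 6.6-fold lower number from compound 3 to compound 4 (0.82 log units; beyond the scatter) separates two benzyl compounds with different ring substituents. No evidence here explains that difference. On these data alone, it remains open whether the nitrile itself or its place on the ring counts more, which 4-cyanobenzyl and 3-methoxybenzyl groups could help separate. An unsubstituted benzyl group would also show what either substituent adds.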